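Methoxy in Place of Acetyl: What to Expect for Compound 4

This account rests on a few compounds, and the source may have more. Where it says the series, first, only, none or still open, it means among the compounds named here.

compound 1 `CCOC(=O)c1c(-c2cccc(C(F)(F)F)c2)csc1N`: 93%
compound 2 `CCOC(=O)c1c(N)sc(-c2cccc(C(C)=O)c2)c1-c1cccc(C(F)(F)F)c1`: 68.9%
compound 3 `CCOC(=O)c1c(N)sc(-c2ccc(C(C)=O)cc2)c1-c1cccc(C(F)(F)F)c1`: 64.6%

In an assay on CHO-K1 cells for displacement of a labelled ligand from adenosine receptor A1 (Homo sapiens), tested at 10 uM (on this read-out lower numbers stand for less inhibition and higher numbers for more inhibition at the one concentration tested (going by the name of the read-out)), compound 3 gives 64.6%, the lowest of the three numbers, though its gap to compound 2 is within the scatter; compound 1 lies clearly higher, as a number 28.4 percentage points lower from compound 1 to compound 3 (beyond the scatter) shows. Compound 4 `CCOC(=O)c1c(N)sc(-c2ccc(OC)cc2)c1-c1cccc(C(F)(F)F)c1` differs from compound 3 by methoxy in place of acetyl on an aromatic carbon. For the measured compounds named here, no measured step exchanges one of these two groups for the other: a number 24.1 percentage points lower from compound 1 to compound 2 (beyond the scatter) and a number 28.4 percentage points lower from compound 1 to compound 3 (beyond the scatter) concern the arrival of the acetylphenyl group, and a number 4.3 percentage points lower from compound 2 to compound 3 (within the scatter) only its position. With nothing bearing directly on the change, compound 4 is expected to stay near compound 3, with a number 0.6 percentage points lower from compound 3 to compound 4 (within the scatter) not beyond the scatter. The estimate for compound 4 is 64%, between 48% and 80%.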

Compound 4, a percentage reported as inhibition, at one concentration (the size of the read-out at that concentration, not a potency): 81.5%
Compound 4: middle estimate off by 17.5 percentage points, on the low side; measured number outside the range, above it.
By their numbers in this assay, from the lowest: compounds 3 and 2 (each within the scatter of the next); then compound 4; then compound 1.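

In this assay, the choice of group at this place carries weight that moving the acetyl did not show: methoxy in place of acetyl gives a clear change (a number 16.9 percentage points higher from compound 3 to compound 4 (beyond the scatter)). The 4-methoxyphenyl group also separates from 3-acetylphenyl (a number 12.6 percentage points higher from compound 2 to compound 4 (beyond the scatter)), yet the number does not return to that of hydrogen in this place (a number 11.5 percentage points lower from compound 1 to compound 4 (beyond the scatter)). Nothing available here explains this difference. Going by these compounds, whether an amine or a carboxylic acid in place of methoxy would keep the higher number remains open. So does whether any group here can match hydrogen.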